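Replacing a Hydroxyethyl Chain with a Cyclobutylcarbamoyl Amide

The source may report more compounds than this note shows. Statements on the series, on what has been measured and on what is new or still open speak of the compounds shown alone.

Of the compounds shown here, three have so far been measured in an assay for inhibition of RAC-alpha serine/threonine-protein kinase (Homo sapiens), read by HTRF, with a stated time of 1 h; on this read-out higher numbers stand for weaker inhibition and lower numbers for stronger inhibition. Compound 1 `Cn1ncc(Cl)c1-c1cc(C(=O)N[C@@H]2CN[C@H](CCCO)C[C@H]2c2ccc(Cl)c(Cl)c2)oc1Cl` gives 2.56 nM, the lowest of the three numbers. Compound 2 `Cn1ncc(Cl)c1-c1cc(C(=O)N[C@@H]2CNCC[C@H]2c2ccc(C(F)(F)F)cc2)oc1Cl` gives 9.3 nM, and its mirror image, compound 3 `Cn1ncc(Cl)c1-c1cc(C(=O)N[C@H]2CNCC[C@@H]2c2ccc(C(F)(F)F)cc2)oc1Cl`, gives 127 nM. The step of a 14-fold higher number from compound 2 to compound 3 (1.14 log units; beyond the scatter) is large and is tied to the fact that compounds 2 and 3 differ only in the configuration as drawn. Compound 1 sits clearly apart from both, beyond the scatter in each case.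

Compound 4 `Cn1ncc(Cl)c1-c1cc(C(=O)N[C@@H]2CN[C@H](CC(=O)NC3CCC3)C[C@H]2c2ccc(Cl)c(Cl)c2)oc1Cl` awaits measurement. It differs from compound 1 by cyclobutylcarbamoyl in place of 2-hydroxyethyl on a saturated chain carbon bound to a saturated ring carbon. Going by the values given here, no measured step touches this part of the structure: the only measured step, from compound 2 to compound 3, inverts configuration and leaves every group where it stands, so it offers no guide to exchanging the chain. The expectation therefore rests on the value of compound 1 alone, with a wide range to reflect the missing evidence. Compound 4 is expected to give 3 nM, between 0.8 nM and 12 nM. The expected step of a 1.2-fold higher number from compound 1 to compound 4 (0.07 log units; within the scatter) is estimated to stay within the scatter, in neither direction.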

Compound 4, half-maximal inhibitory concentration: 7.98 nM
The estimate for compound 4 lay 2.7-fold (0.42 log units) below the measured number, and the stated range covers the measured number.
By their numbers in this assay, from the lowest: compound 1; then compounds 4 and 2 (each within the scatter of the next); then compound 3.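

In this assay the exchange of 2-hydroxyethyl for cyclobutylcarbamoyl gives a 3.1-fold higher number from compound 1 to compound 4 (0.49 log units; beyond the scatter) as a modest step beyond the scatter, so this saturated chain carbon does respond to what it carries. The entering group adds heavy atoms and a four-membered ring while the hydrogen-bond donor and acceptor counts stay equal, and compound 4 still gives 7.98 nM in the same low range as compound 1, so a larger group with a ring is accepted here at a modest cost. Nothing measured on these compounds accounts for this step.

As far as these compounds go, whether the step goes with the cyclobutyl ring or with the amide itself stays open, since the two enter together. A plain methyl amide, a carboxylic acid or an amine on the same chain would help to separate them, and a longer chain ending in the same amide would show how far the group can reach.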